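From 4-fluorophenyl to 3,4,5-trifluorophenyl on compound 3

The compounds below may be only part of what the source reports. "The series", "measured", "known", "first", "only" and "open" are said of these compounds alone.

In an ADME assay on HEK293 cells (Homo sapiens) for cytotoxicity, with a stated time of 72 h (a higher number here means that more compound is needed for the effect, a lower number that less compound is needed), compound 1 `C=C[C@@](C)(/C=C/c1ccc(OC)cc1)CCC=C(C)C` gives > 36600 nM, which is a limit and not a number. In this assay compound 2 `C=C[C@@](C)(/C=C/c1ccc(OS(=O)(=O)C(F)(F)F)cc1)CCC=C(C)C` gives > 36600 nM, again only a limit. In this assay compound 3 `C=C[C@@](C)(/C=C/c1ccc(Nc2ccc(F)cc2)cc1)CCC=C(C)C` gives > 36600 nM, also a limit, so it cannot be ranked against the other two.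

Compound 4 `C=C[C@@](C)(/C=C/c1ccc(Nc2cc(F)c(F)c(F)c2)cc1)CCC=C(C)C` carries 3,4,5-trifluorophenyl in place of 4-fluorophenyl on a nitrogen on an aromatic ring. The nearest evidence comes from a step that the two limits leave unreadable from compound 1 to compound 3 and a step that the two limits leave unreadable from compound 2 to compound 3, with a step that the two limits leave unreadable from compound 1 to compound 2 as the remaining comparison. None of these gives a size, and none tests added fluorine on this ring.

The expectation for compound 4 is therefore no clear change in this assay, because of the limit of > 36600 nM in this assay, at which 3 of the 3 values shown sit. The estimated change is a number no higher from compound 3 to compound 4 (the limit leaves the size open), with no direction expected beyond the scatter. Compound 4 is estimated at 36600 nM, with an expected range from 18000 nM to 73000 nM.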

Compound 4, half-maximal effective concentration: > 36600 nM
Compound 4: no number, only a limit; the forecaster's own chance of this, stated with the estimate: 85%; the middle value sits exactly at the limit.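

Compound 3 and compound 4 both give only a limit in this assay, so the step between them cannot be read, and neither can any other step here: the limit of > 36600 nM in this assay, at which 4 of the 4 values shown sit. The compounds shown leave open what concentration of any of them produces the effect, and whether 3,4,5-trifluorophenyl in place of 4-fluorophenyl changes it.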